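A few compounds are considered here, and "the series" means these few. Any claim that something is new, unique, unknown or untested is made for them only; others in the source may bear on it.

Compounds measured so far:
Compound 1 `c1ccc(CO/N=C2/C(c3c[nH]c4ccccc34)=Nc3ccccc32)cc1`: 21400 nM
Compound 2 `Fc1ccc2c(c1)/C(=N\OCc1ccccc1)C(c1c[nH]c3ccc(F)cc13)=N2`: 13300 nM

Both compounds were tested in a functional assay on SPCA2 cells (Homo sapiens) for cytotoxicity, read by MTT assay, with a stated time of 2 days; on this read-out lower numbers stand for stronger inhibition and higher numbers for weaker inhibition. Only these two numbers are available, and compound 2 at 13300 nM lies within the usual scatter of compound 1 at 21400 nM. The two cannot be told apart on this read-out, and both sit in the same broad range.

The next compound to be tested is compound 3 `Cc1ccc(CO/N=C2/C(c3c[nH]c4ccc(F)cc34)=Nc3ccc(F)cc32)cc1`. It keeps the structure of compound 2 except for methyl in place of hydrogen on an aromatic carbon, which turns the benzyl group into a 4-methylbenzyl group, with the methyl para to a large group: methyl in place of hydrogen on an aromatic carbon.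

For the measured compounds named here, no pair of measured compounds shows what this kind of change does, so the data give no direction for it. In this assay, no step beyond the scatter is expected. The estimated step is a 1.1-fold lower number from compound 2 to compound 3 (0.04 log units; within the scatter), which is expected to stay within the scatter. For compound 3 the expected value is 12000 nM, with an estimated range from 5500 nM to 26000 nM.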

Compound 3, half-maximal inhibitory concentration: 11000 nM
Compound 3: the middle estimate sits 1.1-fold (0.04 log units) above what was measured; low and high end bracket the measured number.
By their numbers in this assay, from the lowest: compounds 3, 2 and 1 (each within the scatter of the next).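

Methyl in place of hydrogen on an aromatic carbon of the benzyl group, para to a large group, gives a 1.2-fold lower number from compound 2 to compound 3 (0.08 log units; within the scatter) in this assay. For the compounds shown here, this is the first reading of any single change, and it shows that this one added carbon, turning benzyl into 4-methylbenzyl, leaves the number indistinguishable from that of the parent on this read-out, so the position tolerates a methyl without a change that can be told from the scatter. Nothing at hand says why the number holds steady here.

A single small group at a single place leaves open whether the position stays this silent with something else in that spot, such as a methoxy group, a chlorine, a trifluoromethyl group, an amine, a carboxylic acid or a longer chain. It also leaves open whether methyl on another carbon of the same ring, or the same change on the core of compound 1, would read the same way.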